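The source may report more compounds than this note shows. Statements on the series, on what has been measured and on what is new or still open speak of the compounds shown alone.

In an assay on CHO cells for antagonist activity at transient receptor potential cation channel subfamily V member 1 (Homo sapiens), read by FLIPR (a higher number here means a weaker inhibitor, a lower number a stronger inhibitor), compound 3 `Cc1cccc(C(C(=O)NCc2ccc(C(F)(F)F)nc2N2CCC(C)CC2)c2ccc(NS(C)(=O)=O)c(F)c2)c1` gives 0.1 nM, the lowest of the three numbers; compound 2 `CC1CCN(c2nc(C(F)(F)F)ccc2CNC(=O)C(c2ccccc2)c2ccc(NS(C)(=O)=O)c(F)c2)CC1` gives 1.3 nM and compound 1 `CC1CCN(c2nc(C(F)(F)F)ccc2CNC(=O)C(c2ccc(NS(C)(=O)=O)c(F)c2)C2CCCC2)CC1` gives 88.7 nM. Compound 4 `Cc1ccc(CC(C(=O)NCc2ccc(C(F)(F)F)nc2N2CCC(C)CC2)c2ccc(NS(C)(=O)=O)c(F)c2)cc1` differs from compound 3 by 4-methylbenzyl in place of 3-methylphenyl on a saturated chain carbon bound to an aromatic carbon and a carbonyl carbon. Within the data shown here, the steps that bear on this place are a 68-fold lower number from compound 1 to compound 2 (1.83 log units; beyond the scatter) and an 890-fold lower number from compound 1 to compound 3 (2.95 log units; beyond the scatter), both large and in the same direction, while a 13-fold lower number from compound 2 to compound 3 (1.11 log units; beyond the scatter) shows that the methyl on the aromatic carbon carries much of that gain. Among the measured compounds shown here, no measured step inserts a saturated carbon at this place or moves the methyl, so the size is open; a partial loss is expected for compound 4, with a 10-fold higher number from compound 3 to compound 4 (1.00 log units; beyond the scatter). Compound 4 is expected at 1 nM, between 0.2 nM and 6 nM.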

Compound 4, inhibition constant: "active" (no number reported)
For compound 4 the study gives words and no number, so the estimate cannot be set against anything.
By their numbers in this assay, from the lowest: compound 3; then compound 2; then compound 1.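

Among these compounds, compound 4 is reported only as active in this assay, with no number, so no step from compound 3 can be read. No measured evidence bears on this result. As far as these compounds go, the size and direction of the change with 4-methylbenzyl in place of 3-methylphenyl remain open.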